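A few compounds are considered here, and "the series" means these few. Any claim that something is new, unique, unknown or untested is made for them only; others in the source may bear on it.

Measured so far in an ADME assay on L1210/0 cells (Mus musculus) for cytotoxicity, with a stated time of 48 h; on this read-out lower numbers stand for stronger inhibition and higher numbers for weaker inhibition:
- compound 1, `O=c1[nH]c(=O)n([C@H]2C[C@H](O)[C@@H](CO)O2)cc1CO`: 9180 nM
- compound 2, `O=C(CI)NCc1cn([C@H]2C[C@H](O)[C@@H](CO)O2)c(=O)[nH]c1=O`: 107000 nM
- compound 3, `N#Cc1cn([C@H]2C[C@H](O)[C@@H](CO)O2)c(=O)[nH]c1=O`: a limit only

For compound 3 this assay reports just the limit > 200000 nM and no number; it stands at the weak end of the series, and (the limit of > 200000 nM in this assay, at which 1 of the 3 values shown sits).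

Compound 4, `CC#Cc1cn([C@H]2C[C@H](O)[C@@H](CO)O2)c(=O)[nH]c1=O`, differs from compound 3 by prop-1-yn-1-yl in place of cyano on an aromatic carbon. Within the data shown here, no measured step covers a change at the cyano position itself. Among the measured compounds shown here, the steps that bear on the site are an at least 21-fold higher number from compound 1 to compound 3 (1.33 log units; beyond the scatter) and a 12-fold higher number from compound 1 to compound 2 (1.07 log units; beyond the scatter), both leading away from the hydroxymethyl of compound 1, while an at least 1.8-fold higher number from compound 2 to compound 3 (0.27 log units; that floor lies within the scatter) is small. A modest move to lower numbers is expected for compound 4, an at least 1.8-fold lower number from compound 3 to compound 4 (0.25 log units; that floor lies within the scatter). Compound 4 is therefore estimated at 110000 nM, in the range 25000 nM to 400000 nM.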

Compound 4, half-maximal inhibitory concentration: > 200000 nM
Compound 4 was reported as a limit; the forecaster's own chance of this, stated with the estimate: 40%; at least 1.8-fold (0.25 log units) between middle value and limit.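

In this assay, the all-carbon prop-1-yn-1-yl, like cyano, gives a limit and not a number: the limit of > 200000 nM in this assay, at which 2 of the 4 values shown sit. The step from compound 3 to compound 4 cannot be read, so this change has no readable size. Replacing hydroxymethyl gives an at least 21-fold higher number from compound 1 to compound 4 (1.33 log units; beyond the scatter), whereas replacing the (((iodomethyl)carbonyl)amino)methyl group gives an at least 1.8-fold higher number from compound 2 to compound 4 (0.27 log units; that floor lies within the scatter).

As far as these compounds go, how far compound 3 and compound 4 lie past the limit stays open. Also open, from the compounds shown here alone, is whether an aminomethyl group, a carboxylic acid or a longer chain ending in hydroxy at this position would return a measurable number.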